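This account rests on a few compounds, and the source may have more. Where it says the series, first, only, none or still open, it means among the compounds named here.

Three compounds sharing one core differ only in the aryl group carried on an aromatic carbon of that core. In a functional assay on A549 cells (Homo sapiens) for antiproliferative activity, read by MTT assay, with a stated time of 72 h (a higher number here means a weaker inhibitor, a lower number a stronger inhibitor), compound 1 `COc1cc(-n2cnc3ccc(-c4cccc(F)c4)cc32)cc(OC)c1OC` gives 5270 nM. In this assay compound 2 `COc1ccccc1-c1ccc2ncn(-c3cc(OC)c(OC)c(OC)c3)c2c1` gives 4320 nM, and the step of a 1.2-fold lower number from compound 1 to compound 2 (0.09 log units; within the scatter) stays within the scatter. Compound 3 `COc1cc(-n2cnc3ccc(-c4ccc(Cl)cc4Cl)cc32)cc(OC)c1OC` reaches only > 10000 nM in this assay, which is a limit of the assay and not a number. Compound 3 thus sits at the limit of > 10000 nM in this assay, at which 1 of the 3 values shown sits, so the steps of an at least 1.8-fold higher number from compound 1 to compound 3 (0.27 log units; that floor lies within the scatter) and an at least 2.3-fold higher number from compound 2 to compound 3 (0.36 log units; beyond the scatter) are known only as floors, the latter already beyond the scatter.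

Compound 4 `CCOc1ccc(-c2ccc3ncn(-c4cc(OC)c(OC)c(OC)c4)c3c2)cc1` is not yet measured. It differs from compound 3 by 4-ethoxyphenyl in place of 2,4-dichlorophenyl on an aromatic carbon. For the measured compounds named here, the steps that bear on it are the two rises into compound 3, which show that the 2,4-dichlorophenyl is the only aryl group so far that pushes the number past the assay range, while the 3-fluorophenyl and 2-methoxyphenyl of compound 1 and compound 2 stay near each other. Replacing the 2,4-dichlorophenyl is therefore expected to bring the number back down, with a step of an at least 1.6-fold lower number from compound 3 to compound 4 (0.22 log units; that floor lies within the scatter) expected. Compound 4 is estimated to give 6000 nM in this assay, with a range from 2500 nM to 20000 nM.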

Compound 4, half-maximal inhibitory concentration: 8550 nM
The estimate for compound 4 lay 1.4-fold (0.15 log units) below the measured number, and the stated range covers the measured number.
By their numbers in this assay, from the lowest: compounds 2, 1 and 4 (each within the scatter of the next). At a limit, above all of these: compound 3.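

Set in place of the 2,4-dichlorophenyl, the 4-ethoxyphenyl gives a step known only as a floor, an at least 1.1-fold lower number from compound 3 to compound 4 (0.06 log units; that floor lies within the scatter), so its true size cannot be read. Against the other two aryl groups, the steps of a 2.0-fold higher number from compound 2 to compound 4 (0.30 log units; within the scatter) and a 1.6-fold higher number from compound 1 to compound 4 (0.21 log units; within the scatter) both stay within the scatter, so in this assay compounds 1, 2 and 4 cannot be told apart, although the 4-ethoxyphenyl is a new group at this position, and compound 3 alone goes against this. Compound 3 remains a limit of the assay and not a number: the limit of > 10000 nM in this assay, at which 1 of the 4 values shown sits.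

From the compounds shown here alone, whether an amine or a carboxylic acid on this aryl ring, or an alkoxy chain longer than ethoxy, would move the number beyond the scatter stays open. So does the effect of a saturated ring such as piperidine in place of the aryl group.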